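Piperazine to imidazole at the chain end of compound 1

The source may report more compounds than this note shows. Statements on the series, on what has been measured and on what is new or still open speak of the compounds shown alone.

Compound 1 `O=C1c2c[n+]([O-])c3ccccc3c2C(=O)c2c1c1ccccc1n2CCCCN1CCNCC1` was tested in a functional assay on MCF7 cells (Homo sapiens) for cytotoxicity, read by MTT assay, with a stated time of 72 h (a higher number here means a weaker inhibitor, a lower number a stronger inhibitor), where compound 1 gives 12000 nM. Two other compounds of the same core are known in this assay: compound 2 `CC1(C)OC[C@H](Cn2cc(Cn3c4c(c5ccccc53)C(=O)c3c[n+]([O-])c5ccccc5c3C4=O)nn2)O1` gives 530 nM, and compound 3 `O=C1c2c[n+]([O-])c3ccccc3c2C(=O)c2c1c1ccccc1n2Cc1cn([C@@H]2O[C@H](CO)[C@@H](O)[C@H](O)[C@H]2O)nn1` gives 590 nM. Compound 1 thus stands with the highest number of the three, beyond the scatter from both, so it is the weakest inhibitor of this set. Going by the values given here, the one step between measured compounds, from compound 2 to compound 3, is a 1.1-fold higher number from compound 2 to compound 3 (0.05 log units; within the scatter); it concerns a swap on the triazole-bearing side chain and says nothing about the basic chain end of compound 1.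

Compound 4 `O=C1c2c[n+]([O-])c3ccccc3c2C(=O)c2c1c1ccccc1n2CCCCn1ccnc1` differs from compound 1 in one place: 1H-imidazol-1-yl in place of piperazin-1-yl on a saturated chain carbon, four bonds along the chain from an aromatic nitrogen. Among the compounds with values here, no measured pair here shows the same change or anything near it, so the size and direction of the step in this assay cannot be read from the known steps; the expectation rests on the shared core alone and is wide. Compound 4 is therefore expected near compound 1, with the step of a 1.5-fold lower number from compound 1 to compound 4 (0.18 log units; within the scatter) counted as uncertain. The estimate for compound 4 is 8000 nM, within a range from 2000 nM to 30000 nM.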

Compound 4, half-maximal inhibitory concentration: 130 nM
Estimate against measurement, compound 4: 62-fold (1.79 log units) above; the whole stated range lies above it.
By their numbers in this assay, from the lowest: compound 4; then compounds 2 and 3 (each within the scatter of the next); then compound 1.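

In this assay, the group on a saturated chain carbon, four bonds along the chain from an aromatic nitrogen, proves decisive: 1H-imidazol-1-yl in place of piperazin-1-yl gives a 92-fold lower number from compound 1 to compound 4 (1.97 log units; beyond the scatter) and the step is large. Going by these compounds alone, the only earlier step, a 1.1-fold higher number from compound 2 to compound 3 (0.05 log units; within the scatter), lay within the scatter and concerned a different side chain, so this is the first step in the set to show that the number for this core can move substantially with a change of substituent. The change replaces a six-membered non-aromatic ring bearing a hydrogen-bond donor with a five-membered aromatic ring bearing none, and nothing available here bears on why the number falls.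

As far as these compounds go, what remains open is which part of the change carries the step: a piperidin-1-yl, morpholin-4-yl or 4-methylpiperazin-1-yl group, or a 1H-pyrazol-1-yl ring, at the same place would begin to separate ring type from the ring amine hydrogen. From the compounds shown here alone, it is also open whether 1H-imidazol-1-yl would keep its effect on a shorter or longer chain, such as a propyl or hexyl linker.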